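Triazole N-substituent swap on the trifluoromethyl chromene core

The source may hold more compounds than are shown below. What is called first, only, known or untested is meant among the compounds shown, and "the series" means these compounds.

Measured so far:
compound 1, `CCOC(=O)C1=Cc2ccccc2OC1(OCc1cn(-c2cccc(OC)c2)nn1)C(F)(F)F`, > 150000 nM
compound 2, `Cc1ccc(-c2cc(COC3(C(F)(F)F)Oc4ccccc4C=C3C(=O)O)on2)cc1`, 51200 nM
compound 3, `CCOC(=O)C1=Cc2ccccc2OC1(OCc1cc(-c2ccc(Br)cc2)no1)C(F)(F)F`, > 150000 nM

In a functional assay on A549 cells (Homo sapiens) for inhibition, read by MTT assay, with a stated time of 24 h (a higher number here means a weaker inhibitor, a lower number a stronger inhibitor), compound 1 gives only a limit, > 150000 nM, and not a number. The same holds for compound 3, whose value > 150000 nM is a limit. For the measured compounds named here, compound 2 is the only one with a number, 51200 nM. Going by the values given here, compound 1 therefore stands at the limit of > 150000 nM in this assay, at which 2 of the 3 values shown sit; no measured step between compounds that differ in one place exists, so nothing is known about how any single change moves the read-out.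

Compound 4, `CCOC(=O)C1=Cc2ccccc2OC1(OCc1cn(CC(=O)Nc2ccccc2F)nn1)C(F)(F)F`, has not been measured. It differs from compound 1 by ((2-fluorophenyl)carbamoyl)methyl in place of 3-methoxyphenyl on an aromatic nitrogen. The rest of the molecule is unchanged. Among the compounds with values here, with two of three values sitting at the limit and no step to lean on, no movement beyond the scatter is expected from this change, in either direction, and a limit again is the more likely outcome.

The half-maximal inhibitory concentration of compound 4 in this assay is estimated at 140000 nM, expected between 50000 nM and 300000 nM. The expected step of an at least 1.0-fold lower number from compound 1 to compound 4 (0.02 log units; that floor lies within the scatter) is none beyond the scatter.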

Compound 4, half-maximal inhibitory concentration: 50100 nM
Estimate against measurement, compound 4: 2.8-fold (0.45 log units) above; the range from low to high includes it.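

In this assay, for the compounds shown here, the aromatic nitrogen of the five-membered aromatic ring with 3 nitrogen is the first place with a readable single change: ((2-fluorophenyl)carbamoyl)methyl in place of 3-methoxyphenyl gives an at least 2.9-fold lower number from compound 1 to compound 4 (0.47 log units; beyond the scatter). The substituent at this position can therefore move the read-out beyond the scatter on an otherwise unchanged molecule, and compound 4 has a number where compound 1 does not. The step is only a floor on the true size because compound 1 stands at a limit and not a number: the limit of > 150000 nM in this assay, at which 2 of the 4 values shown sit.

The change replaces an aryl group on the ring nitrogen with a longer group that carries an amide hydrogen and a fluorine, so the compounds shown do not separate the contributions of the carbamoylmethyl unit and the 2-fluorophenyl ring. Still open, from the compounds shown here alone, is how the read-out responds to a plain phenyl on the amide, a chlorine in place of the fluorine, a tertiary amide that lacks the amide hydrogen, or a longer chain in the linker.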